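Swapping a halogenated benzyl for a furylmethyl on a terpene amine

This account rests on a few compounds, and the source may have more. Where it says the series, first, only, none or still open, it means among the compounds named here.

Three analogues sharing one core have been measured in a functional assay on BMMC cells (Mus musculus, strain C57BL/6) for inhibition, with stated times of 5 days and 48 h; a higher number here means a weaker inhibitor, a lower number a stronger inhibitor. Compound 1 `C=C1CC[C@@H]2[C@](C)(CNCc3ccc(O)c(O)c3)[C@H](O)CC[C@@]2(C)[C@@H]1/C=C/C1=CCOC1=O` gives 9440 nM. Compound 2 `C=C1CC[C@@H]2[C@](C)(CNCc3ccc(F)cc3)[C@H](O)CC[C@@]2(C)[C@@H]1/C=C/C1=CCOC1=O` gives 350 nM, and compound 3 `C=C1CC[C@@H]2[C@](C)(CNCc3ccc(Cl)cc3)[C@H](O)CC[C@@]2(C)[C@@H]1/C=C/C1=CCOC1=O` gives 420 nM. Compound 3 thus holds the second highest number of the three, separated from compound 2 by a gap within the scatter and from compound 1 by a gap well beyond it; the two halogenated compounds sit close together, with a 1.2-fold higher number from compound 2 to compound 3 (0.08 log units; within the scatter).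

The next compound, compound 4 `C=C1CC[C@@H]2[C@](C)(CNCc3ccco3)[C@H](O)CC[C@@]2(C)[C@@H]1/C=C/C1=CCOC1=O`, differs from compound 3 in one place: furan-2-yl in place of 4-chlorophenyl on a saturated chain carbon bound to an amine nitrogen. Among the compounds with values here, no measured step exchanges a phenyl ring for a five-membered heteroaromatic ring, so the nearest guidance is indirect. a 27-fold lower number from compound 1 to compound 2 (1.43 log units; beyond the scatter) and a 22-fold lower number from compound 1 to compound 3 (1.35 log units; beyond the scatter) show that the identity of the aromatic group on the amine can move the number a great deal, whereas a 1.2-fold higher number from compound 2 to compound 3 (0.08 log units; within the scatter) shows that a small exchange within that group changes little. The change here replaces the whole ring. A moderate step is expected, most likely toward a higher number, with a 1.9-fold higher number from compound 3 to compound 4 (0.28 log units; within the scatter) as the estimate. Compound 4 is therefore expected to give about 800 nM, in the range 250 nM to 2600 nM.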

Compound 4, half-maximal inhibitory concentration: 1830 nM
Beside the measured number, compound 4's estimate is 2.3-fold (0.36 log units) below it; measured number inside the range.
By their numbers in this assay, from the lowest: compounds 2 and 3 (each within the scatter of the next); then compound 4; then compound 1.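

Replacing the whole aromatic ring on a saturated chain carbon bound to an amine nitrogen gives a 4.4-fold higher number from compound 3 to compound 4 (0.64 log units; beyond the scatter) and a 5.2-fold higher number from compound 2 to compound 4 (0.72 log units; beyond the scatter) in this assay, so this position responds to a ring exchange far more than to the chloro and fluoro exchange seen earlier. The same ring gives a 5.2-fold lower number from compound 1 to compound 4 (0.71 log units; beyond the scatter) against the 3,4-dihydroxyphenyl analogue, which places furan-2-yl between the halogenated phenyl rings and that group on this scale. Nothing available here accounts for this ordering.

The loss of the halogen, the smaller ring and the ring oxygen all arrive together in compound 4, and the compounds shown do not separate them. An unsubstituted phenyl or a thiophen-2-yl at the same place would bear on that question.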